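The source may hold more compounds than are shown below. What is called first, only, known or untested is meant among the compounds shown, and "the series" means these compounds.

Measured in an ADME assay on MT4 cells (Homo sapiens) for cytotoxicity, read by MTT assay, with a stated time of 5 days; a lower number here means that less compound is tolerated, a higher number that more compound is tolerated:
compound 1 `COc1cc2nc(SCC(=O)Nc3ccc(C)cc3)nc(Nc3c(Cl)cc(/C=C/C#N)cc3Cl)c2cc1OC`: 2540 nM
compound 2 `COc1cc2nc([S+]([O-])CC(=O)Nc3ccc(F)cc3)nc(Nc3c(C)cc(/C=C/C#N)cc3C)c2cc1OC`: 27400 nM
compound 3 `COc1cc2nc([S+]([O-])CC(=O)Nc3cccc(Cl)c3)nc(Nc3c(Cl)cc(/C=C/C#N)cc3Cl)c2cc1OC`: 68900 nM

Compound 3 gives the highest of the three numbers, 68900 nM. Compound 2 gives 27400 nM and compound 1 gives 2540 nM, and both gaps to compound 3 lie beyond the usual scatter. Among the measured compounds shown here, no two measured compounds differ in one place only, so no measured step isolates a single change.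

The next compound is compound 4 `COc1cc2nc([S+]([O-])CC(=O)Nc3ccccc3C#N)nc(Nc3c(Cl)cc(/C=C/C#N)cc3Cl)c2cc1OC`. Its difference from compound 3 is 2-cyanophenyl in place of 3-chlorophenyl on an amide-type nitrogen. The rest of the structure is unchanged. For the measured compounds named here, the series holds no measured example of this exchange, so the expectation is weakly founded.

Compound 3, at 68900 nM, sits at the top of the numbers seen so far, while compound 2 lies lower at 27400 nM. On that basis, a small step toward a lower number in this assay is expected, not beyond the scatter. The estimated change is a 1.7-fold lower number from compound 3 to compound 4 (0.24 log units; within the scatter). The expected value for compound 4 is 40000 nM, with an estimated range of 12000 nM to 100000 nM.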

Compound 4, half-maximal cytotoxic concentration: > 206000 nM
Compound 4: no number, only a limit (the forecaster's own chance of this, stated with the estimate: 20%); at least 5.1-fold (0.71 log units) between middle value and limit.
By their numbers in this assay, from the lowest: compound 1; then compound 2; then compound 3. At a limit, above all of these: compound 4.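

Among the compounds shown here, compound 3 and compound 4 form the first pair that differs in one place only, so the group on the amide-type nitrogen can now be read on its own. In this assay, 2-cyanophenyl in place of 3-chlorophenyl on that nitrogen gives an at least 2.9-fold higher number from compound 3 to compound 4 (0.47 log units; beyond the scatter), and the rest of the structure is unchanged. This shows that the aryl group at this place alone can shift the reading beyond the scatter, which compound 1, compound 2 and compound 3 could not show, and the reading for compound 4 is a limit and not a number: the limit of > 206000 nM in this assay, at which 1 of the 4 values shown sits.

The exchange changes both the substituent and where it stands on the phenyl ring, and the compounds shown do not separate these two changes, so the nitrile cannot be credited by itself. As far as these compounds go, it also stays open whether a carboxylic acid or an amine on the same phenyl ring would give a reading in the same range, and whether 2-cyanophenyl has the same effect with the other groups found on the shared core in compound 1 and compound 2.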